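Carbamoyl group on the phenol oxygen of compound 2

The source may hold more compounds than are shown below. What is called first, only, known or untested is meant among the compounds shown, and "the series" means these compounds.

Compound 1 `CC(C)=CCC1Cc2c(O)cc(=O)n(CCCO)c2CC1(C)C` gives 25.6% in a functional assay on PANC-1 cells (Homo sapiens) for inhibition, read by MTT assay, with a stated time of 24 h, tested at 10 uM; a higher number here means more inhibition at the concentration tested (going by the name of the read-out), a lower number less inhibition; compound 2 `CC(C)=CCC/C(C)=C/CC1Cc2c(O)cc(=O)n(CCCO)c2CC1(C)C` gives 28.7%, and compound 3 `CC(C)=CCC1Cc2c(OCCCNS(=O)(=O)c3ccc(Cl)cc3)cc(=O)n(CCCO)c2CC1(C)C` gives 24.7%. Compound 2 carries the top number of the three, but its gaps to compound 1 and to compound 3 are both within the scatter, so the three are not separated. Compound 4 `CC(C)=CCC/C(C)=C/CC1Cc2c(OC(=O)Nc3ccccc3F)cc(=O)n(CCCO)c2CC1(C)C` differs from compound 2 by (2-fluorophenyl)carbamoyl in place of hydrogen on an oxygen on an aromatic ring, read one bond further out as hydroxy to ((2-fluorophenyl)carbamoyl)oxy. Within the data shown here, the one step in hand, a number 3.1 percentage points higher from compound 1 to compound 2 (within the scatter), concerns another position and is within the scatter; compound 3, substituted on the same oxygen, shows a number close to that of compound 1. No basis exists for a shift beyond the scatter, so compound 4 is expected near compound 2, with a number 1.7 percentage points lower from compound 2 to compound 4 (within the scatter); the estimate for compound 4 is 27%, range 14% to 42%.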

Compound 4, a percentage reported as inhibition, at one concentration (the size of the read-out at that concentration, not a potency): 71.6%
Estimate against measurement, compound 4: 44.6 percentage points below, outside the stated range (above it).
By their numbers in this assay, from the lowest: compounds 3, 1 and 2 (each within the scatter of the next); then compound 4.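

Hydroxy to ((2-fluorophenyl)carbamoyl)oxy on the oxygen of compound 2 gives a number 42.9 percentage points higher from compound 2 to compound 4 (beyond the scatter) in this assay, the only step so far beyond the scatter. Substitution on this oxygen can therefore move the number, which the pair on the shorter chain did not show: compound 1 gives 25.6% and compound 3 gives 24.7%, within the scatter of each other. No measured evidence accounts for the rise.

Still open, on these data alone, is which part of the carbamoyl carries the step, the fluorine, the aromatic ring or the carbamoyl link. Phenylcarbamoyl or acetyl on the same oxygen would separate these.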